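Working notes: permeability expected for compound 4

A few compounds are considered here, and "the series" means these few. Any claim that something is new, unique, unknown or untested is made for them only; others in the source may bear on it.

Measured in an ADME assay on Caco-2 cells (Homo sapiens) for permeability, read by LC-MS, in the apical to basolateral direction, with a stated time of 2 h (a higher number here means that the compound crosses the layer faster, a lower number that the compound crosses the layer more slowly), for this series:
- compound 1 `CCCN(CC1CCOC1)C(=O)c1cc(OC)c2oc(NCc3cccc(Cl)c3)nc2c1` gives 246 nm/s as its entry
- compound 2 `COc1cc(C(=O)N2CC[C@@H](O)C(C)(C)C2)cc2nc(NCc3cccc(Cl)c3)oc12` gives "not determined" (no result reported) as its entry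
- compound 3 `COc1cc(C(=O)N2CC(C)C(O)CC2C)cc2nc(NCc3cccc(Cl)c3)oc12` gives 127 nm/s; "not determined" (no result reported) (2 entries) as its entries

Compound 2 has no single number in this assay and so offers no measured starting point for the step followed here. Compound 3 has one number and one entry without a result (the several entries of compound 3 in this assay, 127 nm/s; "not determined" (no result reported) (2 entries)). The numbers for compound 1 and compound 3 lie within the usual scatter of each other.

Compound 4 `COc1cc(C(=O)N2CC(C)C(O)CC2C2CC2)cc2nc(NCc3cccc(Cl)c3)oc12` has not yet been measured. The change is 2-cyclopropyl-4-hydroxy-5-methylpiperidin-1-yl in place of 4-hydroxy-3,3-dimethylpiperidin-1-yl on a carbonyl carbon and amounts to 2-cyclopropyl-4-hydroxy-5-methylpiperidin-1-yl in place of 4-hydroxy-3,3-dimethylpiperidin-1-yl on a carbonyl carbon. Within the data shown here, no step between measured compounds is available to size this change, and compound 2 has no number to step from. The expectation therefore rests on the two numbers available, from compound 1 (246 nm/s) and compound 3 (127 nm/s; "not determined" (no result reported) (2 entries)). No departure beyond the scatter from that shared range is expected, and no direction can be assigned.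

For compound 4 the estimated permeability is 170 nm/s (expected range 70 nm/s to 400 nm/s) in this assay when measured.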

Compound 4, apparent permeability: 138 nm/s
For compound 4 the middle estimate is 1.2-fold (0.09 log units) above the measured one; the range from low to high includes it.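

Replacing ((oxolan-3-yl)methyl)(propyl)amino with 2-cyclopropyl-4-hydroxy-5-methylpiperidin-1-yl on a carbonyl carbon gives a readable step in this assay (a 1.8-fold lower number from compound 1 to compound 4 (0.25 log units; within the scatter)), so this position accepts an open-chain amide group or a substituted hydroxypiperidine, including one carrying a three-membered carbon ring, without a departure beyond the scatter. Compound 4 also supplies a number for the 2-cyclopropyl-4-hydroxy-5-methylpiperidin-1-yl group, whereas compound 2 has none, so the exchange of 4-hydroxy-3,3-dimethylpiperidin-1-yl for this group still cannot be sized. Nothing in the data shown gives a cause for the reading of compound 4.

The compounds shown leave open how this position would read in this assay with a piperidine lacking the hydroxy group, or with a substituent carrying a basic amine or a carboxylic acid, since every group here is a neutral amide substituent. They also leave open how the separate stereoisomers of 2-cyclopropyl-4-hydroxy-5-methylpiperidin-1-yl would compare with one another.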